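This account rests on a few compounds, and the source may have more. Where it says the series, first, only, none or still open, it means among the compounds named here.

In a functional assay on PC-3 cells (Homo sapiens) for inhibition, read by sulforhodamine B assay, with a stated time of 72 h (on this read-out higher numbers stand for weaker inhibition and lower numbers for stronger inhibition), compound 2 `CC1CCN(C(=O)c2c(N)sc(-c3ccc(Cl)cc3)c2-c2ccc(Cl)cc2)CC1` gives 5750 nM and holds the lower of the two measured numbers, while compound 1 `Nc1sc(-c2ccc(Cl)cc2)c(-c2ccc(Cl)cc2)c1C(=O)N1CCCCC1` gives 14300 nM on the same read-out. Compound 3 `Nc1sc(-c2ccc(Cl)cc2)c(-c2ccc(Cl)cc2)c1C(=O)N1CCOCC1` has morpholin-4-yl in place of 4-methylpiperidin-1-yl on a carbonyl carbon is the whole change. For the measured compounds named here, only one measured step bears on it, a 2.5-fold lower number from compound 1 to compound 2 (0.40 log units; beyond the scatter) when methyl replaced hydrogen on a saturated ring carbon. Compound 3 has no such methyl, so a modest rise is expected, a 3.1-fold higher number from compound 2 to compound 3 (0.50 log units; beyond the scatter) in this assay as estimated. The estimate for compound 3 is 18000 nM with an expected range from 7000 nM to 50000 nM on this read-out.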

Compound 3, half-maximal inhibitory concentration: 11700 nM
For compound 3 the middle estimate is 1.5-fold (0.19 log units) above the measured one; measured number inside the range.
By their numbers in this assay, from the lowest: compound 2; then compounds 3 and 1 (each within the scatter of the next).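

In this assay, the ring on the carbonyl carbon can be exchanged as well as decorated: morpholin-4-yl in place of 4-methylpiperidin-1-yl gives a 2.0-fold higher number from compound 2 to compound 3 (0.31 log units; beyond the scatter). Morpholin-4-yl in place of piperidin-1-yl gives a 1.2-fold lower number from compound 1 to compound 3 (0.09 log units; within the scatter), so the ring oxygen leaves no readable mark, and of these three compounds only compound 2, with its methyl, stands apart. Nothing measured here explains either step. Still open, as far as these compounds go, is how a ring carrying an amine, as in piperazin-1-yl, or a carboxylic acid would behave at this position. From the compounds shown here alone, a longer chain in place of the methyl is equally open.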